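The source may hold more compounds than are shown below. What is called first, only, known or untested is meant among the compounds shown, and "the series" means these compounds.

Compound 1 `O=C(NNc1ccnc2cc(Cl)ccc12)c1ccccc1/N=C/c1ccc(F)cc1` is the least lipophilic of the three measured compounds in a physicochemical assay for lipophilicity, measured as octanol-water partition (a lower number here means a more polar compound, a higher number a more lipophilic compound), where compound 1 gives 5.18. Compound 2 `O=C(NNc1ccnc2cc(Cl)ccc12)c1ccccc1/N=C/c1ccc(Cl)cc1` gives 5.62 in this assay, and compound 3 `O=C(NNc1ccnc2cc(Cl)ccc12)c1ccccc1/N=C/c1ccc(Cl)cc1Cl` gives 6.22. The measured steps all run upward: a number 0.44 log units higher from compound 1 to compound 2 (beyond the scatter), a number 0.60 log units higher from compound 2 to compound 3 (beyond the scatter) and a number 1.04 log units higher from compound 1 to compound 3 (beyond the scatter). The unmeasured compound 4 `CN(C)c1ccc(/C=N/c2ccccc2C(=O)NNc2ccnc3cc(Cl)ccc23)cc1` differs from compound 1 by dimethylamino in place of fluoro on an aromatic carbon. Going by the values given here, none of the measured steps concerns this group; each of them describes chloro replacing fluoro or hydrogen, and they therefore bear only loosely on the change at hand. With the group that enters carrying one hydrogen-bond acceptor and no charge, while the group that leaves carries none, the expected movement in this assay is small, in either direction, and may well stay within the scatter. The estimate for compound 4 is 5.2, with a range from 4.6 to 5.8, an expected step of a number 0.02 log units higher from compound 1 to compound 4 (within the scatter).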

Compound 4, partition coefficient: 5.03
For compound 4 the middle estimate is 0.17 log units above the measured one; the measured number falls inside the stated range.
By their numbers in this assay, from the lowest: compounds 4 and 1 (each within the scatter of the next); then compound 2; then compound 3.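

At this place, on an aromatic carbon para to a large group, dimethylamino is the first group shown that does not lift the number in this assay clear of compound 1: the exchange for fluoro gives a number 0.15 log units lower from compound 1 to compound 4 (within the scatter), even though the entering group has 3 heavy atoms and the leaving group 1. Against the chlorinated compounds the picture is different, with a number 0.59 log units lower from compound 2 to compound 4 (beyond the scatter) and a number 1.19 log units lower from compound 3 to compound 4 (beyond the scatter), so the upward run seen with chloro does not carry over to this group. Nothing at hand bears on the reason for this result.

On these data alone, whether another amine, such as pyrrolidine or morpholine, or a methoxy group would also stay within the scatter of compound 1 remains open. So does the effect of a carboxylic acid at this place on the number.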